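The compounds below may be only part of what the source reports. "The series", "measured", "known", "first", "only" and "open" are said of these compounds alone.

Measured so far in a functional assay on MCF7 cells (Homo sapiens) for cytotoxicity, read by MTT assay, with a stated time of 24 h; on this read-out higher numbers stand for weaker inhibition and lower numbers for stronger inhibition:
Compound 1 `Cn1c(-c2ccc(NC(=O)CCl)cc2)nc(-c2ccccc2)c1-c1ccccc1`: 42.6 ug/mL
Compound 2 `Cn1c(-c2ccc(NC(=O)CSC3=NCCS3)cc2)nc(-c2ccccc2)c1-c1ccccc1`: 26.7 ug/mL

Compound 2 and compound 1 give numbers that lie within the usual scatter of each other, so neither stands apart. Compound 3 `Cn1ccnc1SCC(=O)Nc1ccc(-c2nc(-c3ccccc3)c(-c3ccccc3)n2C)cc1` differs from compound 2 by a group of 6 heavy atoms (4 carbon, 2 nitrogen; one five-membered aromatic ring with 2 hetero atoms) in place of a group of 5 heavy atoms (3 carbon, 1 nitrogen, 1 sulfur; one five-membered non-aromatic ring with 2 hetero atoms), on a sulfur. Within the data shown here, the only measured step, a 1.6-fold lower number from compound 1 to compound 2 (0.20 log units; within the scatter), also swapped the group hanging from the chain carbon next to the carbonyl and stayed within the scatter. Nothing measured speaks directly to the entering group, so no step beyond the scatter is expected in this assay. Compound 3 is therefore estimated at 30 ug/mL, with a range from 12 ug/mL to 75 ug/mL. That estimate would mean an expected step of a 1.1-fold higher number from compound 2 to compound 3 (0.05 log units; within the scatter).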

Compound 3, half-maximal inhibitory concentration: 46.5 ug/mL
Compound 3: the middle estimate sits 1.6-fold (0.19 log units) below what was measured; low and high end bracket the measured number.
By their numbers in this assay, from the lowest: compounds 2, 1 and 3 (each within the scatter of the next).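

In this assay, 1-methyl-1H-imidazol-2-yl in place of the non-aromatic ring on the sulfur gives a 1.7-fold higher number from compound 2 to compound 3 (0.24 log units; within the scatter), so this aromatic ring and that non-aromatic ring cannot be told apart here. (1-Methyl-1H-imidazol-2-yl)sulfanyl in place of chloro gives a 1.1-fold higher number from compound 1 to compound 3 (0.04 log units; within the scatter), so this exchange on the saturated chain carbon also moves the number by no more than repeat measurements would. No measured information is available to explain these numbers. From the compounds shown here alone, whether a phenyl ring or a longer alkyl chain on the sulfur would give a step beyond the scatter remains open.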